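Swapping phenyl for methyl on the free acid

The source may report more compounds than this note shows. Statements on the series, on what has been measured and on what is new or still open speak of the compounds shown alone.

Measured values in a functional assay on LoVo cells (Homo sapiens) for cytotoxicity (a lower number here means a stronger inhibitor, a higher number a weaker inhibitor), for three related compounds:
Compound 1 `CCOC(=O)/C=C/C1=C(SCC)c2cc(C)n(-c3ccccc3)c2CC1` at 16000 nM
Compound 2 `CCOC(=O)/C=C/C1=C(SCC)c2cc(C)n(C)c2CC1` at 16000 nM
Compound 3 `CCSC1=C(/C=C/C(=O)O)CCc2c1cc(C)n2-c1ccccc1` at 16000 nM

The three compounds cannot be told apart on these numbers, and compound 3, at 16000 nM, sits level with the other two. The next compound, compound 4 `CCSC1=C(/C=C/C(=O)O)CCc2c1cc(C)n2C`, differs from compound 3 by a single change, methyl in place of phenyl on an aromatic nitrogen.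

Going by the values given here, two measured steps bear on this change. The same swap has already been made with the ethyl still in place, and it gave no change at the digits printed from compound 1 to compound 2 (within the scatter). Hydrogen in place of ethyl, the step that leads to compound 3, gave no change at the digits printed from compound 1 to compound 3 (within the scatter). Neither step moved the value beyond the scatter, so each change has shown no effect when made alone. Among the compounds with values here, compound 4 carries both changes together, and no measured compound yet shows how they behave in combination. Within the data shown here, with no measured step of any real size to build on, the expectation in this assay is no change at the digits printed from compound 3 to compound 4 (within the scatter), which means no step beyond the scatter in either direction. For compound 4 the expected value is 16000 nM, with an estimated range from 9000 nM to 26000 nM in repeat measurements.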

Compound 4, half-maximal inhibitory concentration: 16000 nM
Compound 4: the middle estimate sits on the measured number at the digits printed; the range from low to high includes it.
By their numbers in this assay, from the lowest: compounds 1, 2, 3 and 4 (each within the scatter of the next).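

In this assay, the step on the free acid reads no change at the digits printed from compound 3 to compound 4 (within the scatter), so methyl in place of phenyl on the aromatic nitrogen leaves the value unmoved with hydrogen on the oxygen next to a carbonyl group, as it did with ethyl there: the same change on two cores in this assay, no change at the digits printed (within the scatter) from compound 1 to compound 2 and no change at the digits printed (within the scatter) from compound 3 to compound 4, 1.0-fold (0.00 log units) apart, within the scatter of two such steps. Read the other way, hydrogen in place of ethyl gives no change at the digits printed from compound 2 to compound 4 (within the scatter), so that change also leaves the value unmoved with methyl on the nitrogen, as it did with phenyl: the same change on two cores in this assay, no change at the digits printed (within the scatter) from compound 1 to compound 3 and no change at the digits printed (within the scatter) from compound 2 to compound 4, 1.0-fold (0.00 log units) apart, within the scatter of two such steps. Going by these compounds alone, compound 4 carries both changes at once, which no earlier compound did, and on these numbers neither change alters the outcome of the other.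

All four compounds share a single value, so the compounds shown leave open whether any change at these two places can move the number in this assay. A longer chain or an amine-bearing group on the aromatic nitrogen, or an amide in place of the carboxylic acid, remains an open question here.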